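Ring Size at the Amide: Compound 2 to Compound 4

The source may hold more compounds than are shown below. What is called first, only, known or untested is meant among the compounds shown, and "the series" means these compounds.

Compound 1, `CCn1c(-c2cnc(C)nc2)nc2c(O[C@H]3CCN(C(=O)C4CC4)C3)ncnc21`: 0.6 L/kg
Compound 2, `CCn1c(-c2cnc(C)nc2)nc2c(N[C@H]3CCN(C(=O)C4CCC4)C3)ncnc21`: 1.3 L/kg
Compound 3, `CCn1c(-c2ccc(C(F)(F)F)nc2)nc2c(O[C@H]3CCN(C(=O)N4CC(OC)C4)C3)ncnc21`: 0.7 L/kg

In an ADME assay (Canis lupus familiaris, strain Beagle) for pharmacokinetics (a lower number here means that more of the compound stays in the plasma, a higher number that more of the compound sits outside the plasma), compound 2 gives 1.3 L/kg, a number that lies beyond the scatter above that of compound 1, while the numbers of compound 2 and compound 3 sit within the scatter of each other. Compound 4, `CCn1c(-c2cnc(C)nc2)nc2c(N[C@H]3CCN(C(=O)C4CC4)C3)ncnc21`, shares the rest of its structure with compound 2 and differs only at the carbonyl carbon: cyclopropyl in place of cyclobutyl on a carbonyl carbon. Among the compounds with values here, no two measured compounds differ in this one place alone, so no measured step sets the size. The step from compound 2 in this assay is expected to stay within the scatter, if anything slightly downward, as a 1.2-fold lower number from compound 2 to compound 4 (0.07 log units; within the scatter). Compound 4 is therefore estimated at 1.1 L/kg, with a range from 0.6 L/kg to 2 L/kg.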

Compound 4, volume of distribution: 1.5 L/kg
The estimate for compound 4 lay 1.4-fold (0.13 log units) below the measured number; low and high end bracket the measured number.
By their numbers in this assay, from the lowest: compounds 1, 3, 2 and 4 (each within the scatter of the next, the first and the last beyond it).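

In this assay, within the data shown here, cyclopropyl in place of cyclobutyl on a carbonyl carbon gives a 1.2-fold higher number from compound 2 to compound 4 (0.06 log units; within the scatter), the first reading of a change at this position alone. For this pair, the size of the carbon ring therefore has no effect that can be told from the scatter. Nothing measured here offers an explanation for this result. From the compounds shown here alone, whether a cyclohexyl group, a longer chain or an amine at this position would shift the number remains open. So does whether the same ring swap would behave alike on another core.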